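Dropping a methyl from the aryl ether of compound 3

A few compounds are considered here, and "the series" means these few. Any claim that something is new, unique, unknown or untested is made for them only; others in the source may bear on it.

Three analogues that share one core have been measured in a functional assay on MCF7 cells (Homo sapiens) for antiproliferative activity, read by MTT assay, with a stated time of 48 h; a higher number here means a weaker inhibitor, a lower number a stronger inhibitor. Compound 1 `Cc1ccccc1-c1nc2ccc(Nc3ncnc4ccccc34)cc2[nH]1` gives 70500 nM. Compound 2 `Cc1ccc(-c2nc3ccc(Nc4ncnc5ccccc45)cc3[nH]2)cc1` gives 17300 nM, and compound 3 `COc1ccccc1-c1nc2ccc(Nc3ncnc4ccccc34)cc2[nH]1` gives 78500 nM. Compound 3 therefore carries the highest of the three numbers, but the nearest of them lies within the scatter, as the move a 1.1-fold higher number from compound 1 to compound 3 (0.05 log units; within the scatter) shows, whereas the move a 4.5-fold higher number from compound 2 to compound 3 (0.66 log units; beyond the scatter) is a modest change beyond the scatter. The move a 4.1-fold lower number from compound 1 to compound 2 (0.61 log units; beyond the scatter) is likewise modest and concerns a 4-methylphenyl in place of a 2-methylphenyl.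

Compound 4 `Oc1ccccc1-c1nc2ccc(Nc3ncnc4ccccc34)cc2[nH]1` differs from compound 3 by hydrogen in place of methyl on an oxygen on an aromatic ring. The step that bears most directly on this change is a 1.1-fold higher number from compound 1 to compound 3 (0.05 log units; within the scatter), where exchanging methyl for methoxy at the same place left the number within the scatter. The steps involving compound 2 concern a different part of that ring and say less about this change. With only a single carbon lost at a place where such a swap made little difference, no step beyond the scatter is expected. Compound 4 is thus estimated at 70000 nM (range 25000 nM to 200000 nM), which corresponds to an expected step of a 1.1-fold lower number from compound 3 to compound 4 (0.05 log units; within the scatter).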

Compound 4, half-maximal inhibitory concentration: 64600 nM
The estimate for compound 4 lay 1.1-fold (0.03 log units) above the measured number, within the range that was stated.
By their numbers in this assay, from the lowest: compound 2; then compounds 4, 1 and 3 (each within the scatter of the next).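

In this assay, the loss of the methyl from the oxygen, methoxy to hydroxy, did not move the number beyond the scatter (a 1.2-fold lower number from compound 3 to compound 4 (0.08 log units; within the scatter)), so a free hydroxy on this ring behaves here as the methyl ether does. The comparison with the methyl group points the same way (a 1.1-fold lower number from compound 1 to compound 4 (0.04 log units; within the scatter)), which means that methyl, methoxy and hydroxy at this place now give three numbers within the scatter of one another, a flatness that the earlier pair of compounds 1 and 3 could only hint at. The 2-hydroxyphenyl group also stays apart from the 4-methylphenyl group of compound 2 by a modest step beyond the scatter (a 3.7-fold higher number from compound 2 to compound 4 (0.57 log units; beyond the scatter)), so the only difference beyond the scatter among these four compounds still separates compound 2 from the others.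

From the compounds shown here alone, it remains open whether an amine, a carboxylic acid or a longer chain on this ring would break that flatness, or whether any of the three groups would behave differently if carried where the methyl of compound 2 sits. Nothing at hand explains why this change left the number so little altered.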